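Swapping a methylphenyl for a naphthyl on the sulfur arm

The source may hold more compounds than are shown below. What is called first, only, known or untested is meant among the compounds shown, and "the series" means these compounds.

Compound 1 `Cc1cccc(CSc2cc(Cl)c(C)cc2S(=O)(=O)/N=C(\N)n2nccc2-c2ccccc2)c1` is the strongest of the three measured compounds in a functional assay on HCT-116 cells (Homo sapiens) for cytotoxicity, read by MTT assay, with a stated time of 72 h (a higher number here means a weaker inhibitor, a lower number a stronger inhibitor), where compound 1 gives 6500 nM. Its nearest neighbour is compound 3 `Cc1cc(-c2ccccc2)n(/C(N)=N/S(=O)(=O)c2cc(C)c(Cl)cc2SCc2ccccc2)n1`, which in this assay gives 10000 nM; that gap is within the scatter, so the two cannot be ranked. The furthest is compound 2 `Cc1cccc(CSc2cc(Cl)c(C)cc2S(=O)(=O)/N=C(\N)n2nc(C)cc2-c2ccccc2)c1`, which gives 34000 nM. The step of a 5.2-fold higher number from compound 1 to compound 2 (0.72 log units; beyond the scatter) and the step of a 3.4-fold lower number from compound 2 to compound 3 (0.53 log units; beyond the scatter) both concern a methyl on an aromatic carbon of the shared core, not the group attached through sulfur.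

Compound 4 `Cc1cc(S(=O)(=O)/N=C(\N)n2nccc2-c2ccccc2)c(SCc2cccc3ccccc23)cc1Cl` differs from compound 1 in one place: naphthalen-1-yl in place of 3-methylphenyl on a saturated chain carbon bound to a sulfur. For the measured compounds named here, no measured step touches this part of the molecule, so nothing here shows how this assay responds to a larger aromatic group on the sulfur arm. The two measured steps that do exist are modest in size, which suggests that single changes in this series move the number only moderately.

With nothing to point in either direction, the step from compound 1 to compound 4 is expected to be small, no change at the digits printed from compound 1 to compound 4 (within the scatter), and probably within the scatter. Compound 4 is therefore estimated to give 6500 nM in this assay, with a range from 2500 nM to 17000 nM.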

Compound 4, half-maximal inhibitory concentration: 7000 nM
For compound 4 the middle estimate is 1.1-fold (0.03 log units) below the measured one; low and high end bracket the measured number.
By their numbers in this assay, from the lowest: compounds 1, 4 and 3 (each within the scatter of the next); then compound 2.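

For the compounds shown here, on a saturated chain carbon bound to a sulfur, naphthalen-1-yl in place of 3-methylphenyl gives, in this assay, a 1.1-fold higher number from compound 1 to compound 4 (0.03 log units; within the scatter), the first measured step at this part of the molecule. The entering group has 2 six-membered aromatic rings of carbon only and 10 heavy atoms against one such ring and 7 heavy atoms, yet the reading stays within the scatter, whereas a methyl on an aromatic carbon of the shared core gives a 5.2-fold higher number from compound 1 to compound 2 (0.72 log units; beyond the scatter). Nothing measured here accounts for the two sulfur-arm groups reading alike.

Going by these compounds, it remains open whether the sulfur arm would give a similar reading with a group other than a carbon-only aromatic one, such as a benzyl carrying an amine or a carboxylic acid, or with a plain longer chain in its place. On these data alone, it is equally open whether naphthalen-1-yl would give the same result on the methyl-bearing core of compound 2, where the number in this assay is already higher.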